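The source may report more compounds than this note shows. Statements on the series, on what has been measured and on what is new or still open speak of the compounds shown alone.

Compound 1 `O=C(O)c1cn(Cc2ccc(-n3ccc4cccnc43)cc2)c2cccc(F)c2c1=O`: 99%
Compound 2 `O=C(O)c1cn(Cc2ccc(-n3ccc4cnccc43)cc2)c2cccc(F)c2c1=O`: 96.9%
Compound 3 `O=C(O)c1cn(Cc2ccc(N3CCOC3=O)cc2)c2cccc(F)c2c1=O`: not yet measured

In an ADME assay on a cell-free system (plasma, Rattus norvegicus) for protein binding, compound 2 gives 96.9%, the larger unbound fraction of the two measured compounds. Compound 3 keeps the shared core and changes one group: a group of 6 heavy atoms (3 carbon, 1 nitrogen, 2 oxygen; one five-membered non-aromatic ring with 2 hetero atoms) in place of a group of 9 heavy atoms (7 carbon, 2 nitrogen; one five-membered aromatic ring with 1 hetero atom, one six-membered aromatic ring with 1 hetero atom), on an aromatic carbon. Within the data shown here, the only guide is a 3.1-fold higher unbound fraction from compound 1 to compound 2 (0.49 log units; beyond the scatter), a modest step at the same place. Among the measured compounds shown here, no measured step shows the effect of the entering 2-oxo-1,3-oxazolidin-3-yl group, so the direction is tentative. A step of similar size towards more free compound is expected, namely a 2.6-fold higher unbound fraction from compound 2 to compound 3 (0.41 log units; beyond the scatter). Compound 3 is estimated at 92%, with an expected range of 80% to 97.5%.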

Compound 3, plasma protein binding: 88.4%
Compound 3: middle estimate off by 1.5-fold (0.16 log units) (unbound fraction), on the low side, within the range that was stated.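

In this assay, replacing either aromatic two-ring group on this aromatic carbon with the non-aromatic 2-oxo-1,3-oxazolidin-3-yl group gives a 3.7-fold higher unbound fraction from compound 2 to compound 3 (0.57 log units; beyond the scatter) and a 12-fold higher unbound fraction from compound 1 to compound 3 (1.06 log units; beyond the scatter) in turn. The free fraction at this place therefore shifts further with a change of the whole group than with the move of a ring nitrogen seen earlier. No available evidence bears on the origin of this shift. As far as these compounds go, compound 3 alters ring type and atom count together, so the contribution of each stays open. From the compounds shown here alone, whether a simple amine or a morpholine here would follow the same direction also stays open.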